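The source may report more compounds than this note shows. Statements on the series, on what has been measured and on what is new or still open speak of the compounds shown alone.

Among the compounds with values here, in an ADME assay on microsomes from liver (Homo sapiens) for metabolic stability, read by LC-MS, using NADPH, with a stated time of 45 min, tested at 3 uM (on this read-out lower numbers stand for a shorter-lived compound and higher numbers for a longer-lived compound), compound 2 (`c1ccc(C(CC2CCCCN2)C2CCCCC2)cc1`) stands lowest of the two numbers so far, with 0.933 h against compound 1 (`C1CCC(C(CC2CCCCN2)C2CC2)CC1`) at 2.07 h on the same read-out. Compound 3 (`Fc1ccc(C(CC2CCCCN2)C2CCCCC2)cc1`) departs from compound 2 by fluoro in place of hydrogen on an aromatic carbon and the change reads as phenyl to 4-fluorophenyl. Within the data shown here, the one measured step, a 2.2-fold lower number from compound 1 to compound 2 (0.35 log units; beyond the scatter), is a different change, phenyl in place of cyclopropyl, so it serves only as a gauge of step size in this small series. Among the measured compounds shown here, no measured pair shows fluoro in place of hydrogen, which leaves the direction weakly supported. A step no larger than that gauge is expected, most likely a slight rise, and the expected step is a 1.3-fold higher number from compound 2 to compound 3 (0.11 log units; within the scatter) on this reading. In this assay the estimate for compound 3 is 1.2 h (range 0.6 h to 2.4 h).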

Compound 3, half-life: 1.32 h
Estimate against measurement, compound 3: 1.1-fold (0.04 log units) below; low and high end bracket the measured number.
By their numbers in this assay, from the lowest: compounds 2, 3 and 1 (each within the scatter of the next, the first and the last beyond it).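

In this assay, fluoro in place of hydrogen on an aromatic carbon, para to a large group, gives a 1.4-fold higher number from compound 2 to compound 3 (0.15 log units; within the scatter), so at this position the change does not separate from repeat measurements. The step of a 1.6-fold lower number from compound 1 to compound 3 (0.20 log units; within the scatter) for 4-fluorophenyl in place of cyclopropyl lies within the scatter, while the step of a 2.2-fold lower number from compound 1 to compound 2 (0.35 log units; beyond the scatter) for phenyl lies beyond it, although the gap between these two steps is the fluoro step itself and is also within the scatter. No supporting data bear on the cause of either step.

The compounds shown leave open whether chloro or methoxy at the same place would read like fluoro. Also open, on these data alone, is whether a carboxylic acid there would give a step beyond the scatter.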